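Deoxyuridine series: five-position alkenyl replacing hydroxymethyl

The source may report more compounds than this note shows. Statements on the series, on what has been measured and on what is new or still open speak of the compounds shown alone.

In an ADME assay on L1210/0 cells (Mus musculus) for cytotoxicity, with a stated time of 48 h (a lower number here means a stronger inhibitor, a higher number a weaker inhibitor), compound 2 `O=c1[nH]c(=O)n([C@H]2C[C@H](O)[C@@H](CO)O2)cc1CO` gives 9180 nM, the lowest of the three numbers measured. Compound 3 `Nc1nc2c(nc(I)n2COCCO)c(=O)[nH]1` gives 111000 nM and compound 1 `Cc1ccc(C(=O)/C=C/c2cc(O)nc(O)n2)cc1` gives 182000 nM, both beyond the scatter from compound 2, so compound 2 is the strongest inhibitor of the three. Compound 4 `CCCC/C=C\c1cn([C@H]2C[C@H](O)[C@@H](CO)O2)c(=O)[nH]c1=O` differs from compound 2 by hex-1-en-1-yl in place of hydroxymethyl on an aromatic carbon. Among the compounds with values here, no measured pair shows this change, so the size of its step is not known from the data. Within the data shown here, compound 2 is the only hydroxymethyl-bearing member, and its value stands apart from compounds 1 and 3. In this assay compound 4 is expected to give a higher number, the step from compound 2 to compound 4 being estimated as an 11-fold higher number from compound 2 to compound 4 (1.04 log units; beyond the scatter). The estimate for compound 4 is 100000 nM, with a range from 20000 nM to 400000 nM.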

Compound 4, half-maximal inhibitory concentration: > 200000 nM
Compound 4: no number, only a limit; the forecaster's own chance of this, stated with the estimate: 25%; middle value at least 2.0-fold (0.30 log units) from the limit.
By their numbers in this assay, from the lowest: compound 2; then compounds 3 and 1 (each within the scatter of the next). At a limit, above all of these: compound 4.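

In this assay compound 4 gives a limit, not a number: > 200000 nM. As far as these compounds go, at this aromatic carbon, two atoms from the ring nitrogen, hex-1-en-1-yl in place of hydroxymethyl gives an at least 21-fold higher number from compound 2 to compound 4 (1.33 log units; beyond the scatter), the first step read at this position, and its full size stays open: the limit of > 200000 nM in this assay, at which 1 of the 4 values shown sits. With the core held constant, the hydroxymethyl compound keeps the lower number.

This single pair leaves open whether the chain length, the double bond or the lost hydroxyl sets the step. An ethyl group, a saturated hexyl chain or an aminomethyl group at this position would separate these.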